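Series notes: aryl for alkyl on the shared core

The source may report more compounds than this note shows. Statements on the series, on what has been measured and on what is new or still open speak of the compounds shown alone.

compound 1 `CCc1nnc([S+]([O-])Cc2ncc(C)c(OC)c2C)o1`: in a functional assay on HUVEC cells (Homo sapiens) for inhibition, read by ELISA (a lower number here means a stronger inhibitor, a higher number a weaker inhibitor), compound 1 gives 12000 nM
compound 2 `CCCc1nnc([S+]([O-])Cc2ncc(C)c(OC)c2C)o1`: in this assay compound 2 gives 10000 nM

Going by the values given here, compound 2 has the lowest of the two numbers, and the only step between measured compounds, a 1.2-fold lower number from compound 1 to compound 2 (0.08 log units; within the scatter), is within the scatter. Compound 3 `COc1c(C)cnc(C[S+]([O-])c2nnc(-c3ccc(F)cc3)o2)c1C` carries 4-fluorophenyl in place of propyl on an aromatic carbon. Among the compounds with values here, the one measured step covers only a small lengthening of the chain, so it says little about an aromatic ring entering at that carbon; no beyond-scatter movement is expected, with wide uncertainty. The estimated step is a 1.4-fold lower number from compound 2 to compound 3 (0.15 log units; within the scatter). Compound 3 is expected to give 7000 nM in this assay, within 1500 nM to 30000 nM.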

Compound 3, half-maximal inhibitory concentration: 14000 nM
Compound 3: the middle estimate sits 2.0-fold (0.30 log units) below what was measured; the measured number falls inside the stated range.
By their numbers in this assay, from the lowest: compounds 2, 1 and 3 (each within the scatter of the next).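

In this assay, 4-fluorophenyl in place of propyl gives a 1.4-fold higher number from compound 2 to compound 3 (0.15 log units; within the scatter) and 4-fluorophenyl in place of ethyl gives a 1.2-fold higher number from compound 1 to compound 3 (0.07 log units; within the scatter) at this aromatic carbon of the five-membered ring. Neither step lies beyond the scatter, so at this position an aromatic ring and a short alkyl chain cannot be told apart in these numbers. No evidence on hand bears on this result. Open, as far as these compounds go, is whether an amine, a carboxylic acid or a longer chain at this carbon would give a step beyond the scatter, and what unsubstituted phenyl would give.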